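Aryl exchange on the aromatic nitrogen: compound 3 to compound 4

A few compounds are considered here, and "the series" means these few. Any claim that something is new, unique, unknown or untested is made for them only; others in the source may bear on it.

Compound 1 `Cc1cccc(-n2nncc2CN2C(=O)C3(C(C#N)=C(N)Oc4c(N)cc5nc6ccccc6nc5c43)c3ccccc32)c1` gives in a functional assay on HCT-116 cells (Homo sapiens) for antiproliferative activity, read by MTT assay, with a stated time of 48 h (a higher number here means a weaker inhibitor, a lower number a stronger inhibitor), a value that is an assay limit, > 50000 nM.
Compound 2 `Cc1ccc(-n2nncc2CN2C(=O)C3(C(C#N)=C(N)Oc4c(N)cc5nc6ccccc6nc5c43)c3ccccc32)cc1C` gives in this assay likewise a limit, > 50000 nM.
Compound 3 `CCc1cccc(CC)c1-n1nncc1CN1C(=O)C2(C(C#N)=C(N)Oc3c(N)cc4nc5ccccc5nc4c32)c2ccccc21` gives in this assay 37600 nM.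

Within the data shown here, compound 3 is thus the only member of the series with a measured number; the other two sit at the limit of > 50000 nM in this assay, at which 2 of the 3 values shown sit. The measured steps that bear on the change examined here are an at least 1.3-fold lower number from compound 1 to compound 3 (0.12 log units; that floor lies within the scatter) and an at least 1.3-fold lower number from compound 2 to compound 3 (0.12 log units; that floor lies within the scatter). Both are readable only as floors, and both floors lie within the scatter, so exchanging the aryl group on the aromatic nitrogen has so far shown no direction that can be trusted. Compound 4 `N#CC1=C(N)Oc2c(N)cc3nc4ccccc4nc3c2C12C(=O)N(Cc1cnnn1-c1c(F)cccc1F)c1ccccc12` differs from compound 3 by 2,6-difluorophenyl in place of 2,6-diethylphenyl on an aromatic nitrogen. Among the measured compounds shown here, no measured compound carries fluorine on that aryl group, and the two steps leading to compound 3 give only weak floors. The expectation for compound 4 is therefore a number close to that of compound 3, with a sizeable chance that only a limit is reported. The step expected in this assay is a 1.2-fold higher number from compound 3 to compound 4 (0.08 log units; within the scatter), a small one. Compound 4 is estimated at 45000 nM, with a range from 20000 nM to 100000 nM.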

Compound 4, half-maximal inhibitory concentration: > 50000 nM
Compound 4: no number, only a limit; the forecaster's own chance of this, stated with the estimate: 45%; middle value at least 1.1-fold (0.04 log units) from the limit.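

In this assay compound 4 gives > 50000 nM, which is a limit and not a number. Set against compound 3, 2,6-difluorophenyl in place of 2,6-diethylphenyl on the aromatic nitrogen gives an at least 1.3-fold higher number from compound 3 to compound 4 (0.12 log units; that floor lies within the scatter), so the only fluorine-bearing aryl group shown adds no measured number at this position, and this change, like the earlier aryl exchanges, shows no direction that can be trusted. The steps to compound 4 from compound 1 and from compound 2 cannot be read, with a limit at both ends, and the series now rests largely on one assay limit: the limit of > 50000 nM in this assay, at which 3 of the 4 values shown sit.

Among these compounds, compound 3 remains the only compound here with a measured number, so it is still open whether any aryl group on this nitrogen can move the result beyond the scatter, or whether the two ethyl groups of compound 3 matter at all. Also open, from the compounds shown here alone, is how the series would read with an amine or a carboxylic acid on this aryl ring, or with longer chains in place of the ethyl groups.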